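From 5-methylfuran-2-yl to thiophen-2-yl on the shared core

The source may hold more compounds than are shown below. What is called first, only, known or untested is meant among the compounds shown, and "the series" means these compounds.

Measured so far in a functional assay on ASPC1 cells (Homo sapiens) for inhibition, read by MTT assay; a higher number here means a weaker inhibitor, a lower number a stronger inhibitor:
- Compound 1 `O=C(CCCCCCC(=O)Nc1nnc(-c2ccco2)s1)NO`: 880 nM
- Compound 2 `Cc1ccc(-c2nnc(NC(=O)CCCCCCC(=O)NO)s2)o1`: 880 nM

Compound 1 and compound 2 stand level, and compound 2 reads 880 nM. The next structure is compound 3 `O=C(CCCCCCC(=O)Nc1nnc(-c2cccs2)s1)NO`, which changes the outer ring: thiophen-2-yl in place of 5-methylfuran-2-yl on an aromatic carbon. Among the measured compounds shown here, only one measured step bears on this, no change at the digits printed from compound 1 to compound 2 (within the scatter), for methyl in place of hydrogen on an aromatic carbon. For the measured compounds named here, no measured step tests a thiophen-2-yl group, so the evidence is thin, and no shift beyond the scatter is expected in this assay. The expected step is a 1.1-fold lower number from compound 2 to compound 3 (0.04 log units; within the scatter). For compound 3 the estimate is 800 nM, with an expected range of 350 nM to 1800 nM.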

Compound 3, half-maximal inhibitory concentration: 880 nM
Compound 3: middle estimate off by 1.1-fold (0.04 log units), on the low side; measured number inside the range.
By their numbers in this assay, from the lowest: compounds 1, 2 and 3 (each within the scatter of the next).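

Exchanging the outer ring itself, and not only adding a methyl to it, leaves the reading in this assay level: no change at the digits printed from compound 2 to compound 3 (within the scatter) for thiophen-2-yl against 5-methylfuran-2-yl, and no change at the digits printed from compound 1 to compound 3 (within the scatter) for thiophen-2-yl against furan-2-yl. So at this position, furan-2-yl, 5-methylfuran-2-yl and thiophen-2-yl cannot be told apart in this cell read-out. Nothing available explains why these three compounds read alike.

Going by these compounds, all three groups are five-membered aromatic rings with one hetero atom, so a six-membered phenyl ring at this position remains open. So does a group of a different kind there, such as an amine or a carboxylic acid.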